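Swapping the Phenol Ring for a Chlorophenyl Ring

A few compounds are considered here, and "the series" means these few. Any claim that something is new, unique, unknown or untested is made for them only; others in the source may bear on it.

Measured so far, in a functional assay on MCF7 cells (Homo sapiens) for antiproliferative activity, read by MTT assay, with a stated time of 24 h; on this read-out higher numbers stand for weaker inhibition and lower numbers for stronger inhibition:
Compound 1 `CC(=O)O[C@@H]1OC(n2nc(-c3ccccc3)n(/N=C/c3ccc(O)cc3)c2=S)[C@@H](C(C)=O)[C@H](OC(C)=O)[C@H]1OC(C)=O` gives 12800 nM.
Compound 2 `COc1cc(/C=N/n2c(-c3ccccc3)n[nH]c2=S)ccc1O` gives 26300 nM.
Compound 3 `COc1cc(/C=N/n2c(-c3ccccc3)nn(C3O[C@@H](OC(C)=O)[C@H](OC(C)=O)[C@@H](OC(C)=O)[C@@H]3C(C)=O)c2=S)ccc1O` gives 9700 nM.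

Compound 3 has the lowest of the three numbers; compound 1 lies within the scatter of it, while compound 2 lies beyond. Compound 4 `CC(=O)O[C@@H]1OC(n2nc(-c3ccccc3)n(/N=C/c3ccc(Cl)cc3)c2=S)[C@@H](C(C)=O)[C@H](OC(C)=O)[C@H]1OC(C)=O` differs from compound 3 in one place: 4-chlorophenyl in place of 4-hydroxy-3-methoxyphenyl on a carbon with a double bond to nitrogen. For the measured compounds named here, only one measured step touches part of this change, a 1.3-fold lower number from compound 1 to compound 3 (0.12 log units; within the scatter), which concerns the methoxy that is now removed. Going by the values given here, no measured pair shows the hydroxyl replaced by chlorine; that half of the change has nothing to rest on. The expectation for compound 4 in this assay is therefore a step of a 1.2-fold higher number from compound 3 to compound 4 (0.09 log units; within the scatter), no change beyond the scatter, with a wide range. Compound 4 is estimated at 12000 nM, between 5000 nM and 30000 nM.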

Compound 4, half-maximal inhibitory concentration: 14100 nM
The estimate for compound 4 lay 1.2-fold (0.07 log units) below the measured number; the measured number falls inside the stated range.
By their numbers in this assay, from the lowest: compounds 3, 1, 4 and 2 (each within the scatter of the next, the first and the last beyond it).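

In this assay, chloro can stand in place of hydroxy on the aromatic ring with no change beyond the scatter: a 1.1-fold higher number from compound 1 to compound 4 (0.04 log units; within the scatter). The full swap of 4-hydroxy-3-methoxyphenyl for 4-chlorophenyl also stays within the scatter, with a 1.5-fold higher number from compound 3 to compound 4 (0.16 log units; within the scatter). So this group can give up its hydrogen-bond donor and acceptors without a readable shift in this assay, though nothing available explains this result.

Still open, from the compounds shown here alone, is whether an amine or a carboxylic acid in place of the chlorine would also stay within the scatter.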